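The source may hold more compounds than are shown below. What is called first, only, known or untested is meant among the compounds shown, and "the series" means these compounds.

Three compounds have been measured in a functional assay on MCF-A cells (Homo sapiens) for cytotoxicity (on this read-out higher numbers stand for weaker inhibition of growth and lower numbers for stronger inhibition of growth), so far:

compound 1 `CSc1ccc(C2=C(c3ccc(O)cc3)C(=O)N3CCCC3C2)cc1` gives > 100000 nM 
compound 2 `CSc1ccc(C2=C(c3ccc(OCC4CO4)cc3)C(=O)N3CCCC3C2)cc1` gives 10000 nM 
compound 3 `CSc1ccc(C2=C(c3ccc(Br)cc3)C(=O)N3CCCC3C2)cc1` gives 8000 nM 

The entry for compound 1 is a limit of the assay and not a number. Compound 3 (8000 nM) and compound 2 (10000 nM) lie within the scatter of each other, so compound 3 stands level with compound 2 on the numbers available.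

Compound 4 `CSc1ccc(C2=C(c3ccc(F)cc3)C(=O)N3CCCC3C2)cc1` carries fluoro in place of bromo on an aromatic carbon, para to a large group, turning 4-bromophenyl into 4-fluorophenyl: fluoro in place of bromo on an aromatic carbon. Among the measured compounds shown here, no measured step makes this exchange directly. The nearest steps change the same place: an at least 12-fold lower number from compound 1 to compound 3 (1.09 log units; beyond the scatter) and an at least 10-fold lower number from compound 1 to compound 2 (1.00 log units; beyond the scatter) are both beyond the scatter and start from the hydroxy compound. Between two very different groups, however, a 1.3-fold lower number from compound 2 to compound 3 (0.10 log units; within the scatter) stays within the scatter. With compound 3 as the starting point, no step beyond the scatter is therefore expected in this assay, with a slight lean towards a higher number. The expected change is a 1.5-fold higher number from compound 3 to compound 4 (0.18 log units; within the scatter) in this estimate. For compound 4 the value is estimated at 12000 nM, within an expected range from 4000 nM to 50000 nM.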

Compound 4, concentration for 50% growth inhibition: 800 nM
Compound 4: middle estimate off by 15-fold (1.18 log units), on the high side; measured number outside the range, below it.
By their numbers in this assay, from the lowest: compound 4; then compounds 3 and 2 (each within the scatter of the next). At a limit, above all of these: compound 1.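

In this assay the two halogens at this position, para to a large group, are not interchangeable (a 10-fold lower number from compound 3 to compound 4 (1.00 log units; beyond the scatter)), although neither group carries a hydrogen-bond donor or acceptor and the earlier exchange of bromo for (oxiran-2-yl)methoxy stayed within the scatter. Fluoro also separates from the (oxiran-2-yl)methoxy group (a 13-fold lower number from compound 2 to compound 4 (1.10 log units; beyond the scatter)), which bromo did not do, so the place proves more sensitive than the earlier compounds showed. Against the hydroxy group the change gives a further step (an at least 120-fold lower number from compound 1 to compound 4 (2.09 log units; beyond the scatter)), which rests on a limit for compound 1 and not on a number: the limit of > 100000 nM in this assay, at which 1 of the 4 values shown sits.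

From the compounds shown here alone, whether the lower number belongs to fluoro alone or extends to chloro, a nitrile or a methyl group at this position stays open. Equally open, going by these compounds, is how an amine or a carboxylic acid would behave there.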